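A fluoro-for-methoxy swap on a heteroaromatic aniline

The source may report more compounds than this note shows. Statements on the series, on what has been measured and on what is new or still open speak of the compounds shown alone.

Within the data shown here, compound 2, with the structure `COc1cc(OC(F)(F)F)ccc1Nc1nc2nonc2nc1O`, sits second highest of the three numbers measured so far. In an assay on mitochondria from L6 cells (Rattus norvegicus) for activation, with a stated time of 90 min (a lower number here means that less compound is needed, a higher number that more compound is needed for the effect), compound 2 gives 3800 nM. Its nearest neighbour is compound 3, `Oc1nc2nonc2nc1Nc1ccc(OCC(F)(F)F)c(F)c1`, which in this assay gives 10400 nM, a higher number beyond the scatter. Furthest away is compound 1, `Fc1cccc(Nc2nc3nonc3nc2Nc2ccccc2F)c1`, which in this assay gives 190 nM, far lower and beyond the scatter. The unmeasured compound 4, `Oc1nc2nonc2nc1Nc1ccc(OC(F)(F)F)cc1F`, differs from compound 2 in one place: fluoro in place of methoxy on an aromatic carbon. Among the measured compounds shown here, no pair of measured compounds differs in a single change, so the effect of this swap can only be guessed from the spread of the three values. Since compound 3, which also carries a fluoro on its aromatic ring, gives 10400 nM, compound 4 is expected to land near compound 2 or somewhat higher; the step from compound 2 to compound 4 is estimated as a 1.4-fold higher number from compound 2 to compound 4 (0.16 log units; within the scatter), modest in size. Compound 4 is accordingly expected to give 5500 nM, with a likely range from 1800 nM to 17000 nM.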

Compound 4, half-maximal effective concentration: 2300 nM
Beside the measured number, compound 4's estimate is 2.4-fold (0.38 log units) above it; measured number inside the range.
By their numbers in this assay, from the lowest: compound 1; then compounds 4 and 2 (each within the scatter of the next); then compound 3.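

In this assay, among these compounds, fluoro in place of methoxy on this aromatic carbon, ortho to a large group, gives a 1.7-fold lower number from compound 2 to compound 4 (0.22 log units; within the scatter), the only single-place comparison available so far. Compound 2 and compound 4 therefore cannot be told apart in this assay, and the position keeps its number within the scatter when the methoxy carbon and oxygen, including its hydrogen-bond acceptor, give way to fluoro. No measurement at hand explains this outcome.

The compounds shown leave open whether an amine, a nitrile or a longer alkoxy chain on this same carbon would move the number beyond the scatter. They also leave open whether the same swap would give a similar result on the core of compound 1, or with a group other than trifluoromethoxy on the ring.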